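From Iodo to Trifluoromethyl: Little Change Expected

The compounds below may be only part of what the source reports. "The series", "measured", "known", "first", "only" and "open" are said of these compounds alone.

Of the compounds shown here, three built on one shared core have been tested in a functional assay on HL-60 cells (Homo sapiens) for antiproliferative activity, with a stated time of 24 h; a lower number here means a stronger inhibitor, a higher number a weaker inhibitor. Compound 1 `NC(=O)c1c(NC(=O)c2ccccc2Cl)sc2c1CCN(C(=S)Nc1cccc3ccccc13)C2` gives 13400 nM, compound 2 `NC(=O)c1c(NC(=O)c2ccccc2Cl)sc2c1CCN(C(=S)Nc1ccccc1F)C2` gives 4970 nM, and compound 3 `NC(=O)c1c(NC(=O)c2ccccc2Cl)sc2c1CCN(C(=S)Nc1ccccc1I)C2` gives 4430 nM. The number for compound 3 is the lowest of the three, but its gap to compound 2 lies within the scatter, while a 3.0-fold lower number from compound 1 to compound 3 (0.48 log units; beyond the scatter). Compound 4 `NC(=O)c1c(NC(=O)c2ccccc2Cl)sc2c1CCN(C(=S)Nc1ccccc1C(F)(F)F)C2` differs from compound 3 by trifluoromethyl in place of iodo on an aromatic carbon. For the measured compounds named here, the one measured step that bears on this place is a 1.1-fold lower number from compound 2 to compound 3 (0.05 log units; within the scatter), where exchanging one halogen for another at this carbon moved the number by no more than the scatter. Compound 4 is therefore expected to show a 1.0-fold higher number from compound 3 to compound 4 (0.01 log units; within the scatter), nothing beyond the scatter. The estimate for compound 4 is 4500 nM, within 2000 nM to 10000 nM.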

Compound 4, half-maximal inhibitory concentration: 10600 nM
Compound 4: the middle estimate sits 2.4-fold (0.37 log units) below what was measured; the measured number lies above the stated range.
By their numbers in this assay, from the lowest: compounds 3 and 2 (each within the scatter of the next); then compounds 4 and 1 (each within the scatter of the next).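

At this position, exchanging one halogen for another was not a guide to every replacement: in this assay the change to trifluoromethyl gives a 2.4-fold higher number from compound 3 to compound 4 (0.38 log units; beyond the scatter) and also a 2.1-fold higher number from compound 2 to compound 4 (0.33 log units; beyond the scatter) on the same carbon. The remaining step is a 1.3-fold lower number from compound 1 to compound 4 (0.10 log units; within the scatter) and so does not separate these two compounds, even though the 2-fluorophenyl and 2-iodophenyl compounds both stand apart from compound 1. No available evidence explains this shift. Open, going by these compounds, is whether a methyl, a methoxy or an amine on this carbon would fall with the two halogens or with trifluoromethyl.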